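The source may hold more compounds than are shown below. What is called first, only, known or untested is meant among the compounds shown, and "the series" means these compounds.

The series rests on a shared core, shown first in compound 1, `C=C[C@@](C)(/C=C/c1ccc(OC)cc1)CCC=C(C)C`. In an ADME assay on HEK293 cells (Homo sapiens) for cytotoxicity, with a stated time of 72 h (a lower number here means that less compound is needed, a higher number that more compound is needed for the effect), compound 1 gives only a limit of the assay, > 36600 nM, and no number. Compound 2, `C=C[C@@](C)(/C=C/c1ccc(O)cc1)CCC=O`, likewise gives only a limit in this assay, > 36600 nM. Compound 3, `C=C[C@@](C)(/C=C/c1ccc(O)c(/C=C/C=C/c2ccccc2)c1)CCC=C(C)C`, also gives only a limit, > 36600 nM. Within the data shown here, every value so far therefore sits at the limit of > 36600 nM in this assay, at which 3 of the 3 values shown sit, and since none of the three measured compounds yields a number, no step between them can be sized or given a direction.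

The next compound, compound 4, `C=C[C@@](C)(/C=C/c1ccc(-c2cccc(F)c2)cc1)CCC=C(C)C`, is still to be measured in this assay. It differs from compound 1 in one place: 3-fluorophenyl in place of methoxy on an aromatic carbon. The methoxy that leaves and the 3-fluorophenyl that enters are the whole of the change; the rest of the core is kept.

Among the measured compounds shown here, with compound 1 and its neighbours all at the limit of > 36600 nM in this assay, at which 3 of the 3 values shown sit, there is no measured step that would point up or down, so for compound 4 no step beyond the scatter is expected, an estimated change of a number no higher from compound 1 to compound 4 (the limit leaves the size open). Compound 4 is thus expected to give about 36600 nM in this assay, within a range from 15000 nM to 90000 nM, and most probably again only a limit rather than a number.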

Compound 4, half-maximal effective concentration: > 36600 nM
Compound 4: a limit, no number (the forecaster's own chance of this, stated with the estimate: 70%); the middle value lies on the limit itself.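

Among these compounds, compound 1 and compound 4 both give only a limit in this assay, so no step between them can be read. The compounds shown leave open what effect 3-fluorophenyl in place of methoxy has on the concentration needed in this assay, and at what concentration any of them would reach the half-maximal effect: the limit of > 36600 nM in this assay, at which 4 of the 4 values shown sit.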